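Moving the bromine on a benzyl sulfide

The source may report more compounds than this note shows. Statements on the series, on what has been measured and on what is new or still open speak of the compounds shown alone.

- compound 1 `Sc1nnc(-c2ccc3c(c2)OCCO3)n1-c1ccccc1` gives 51900 nM
- compound 2 `COc1cccc(CSc2nnc(-c3ccc4c(c3)OCCO4)n2-c2ccccc2)c1` gives the limit > 100000 nM
- compound 3 `Brc1ccccc1CSc1nnc(-c2ccc3c(c2)OCCO3)n1-c1ccccc1` gives the limit > 100000 nM

In a functional assay on HeLa cells (Homo sapiens) for antiproliferative activity, read by MTT assay, with a stated time of 24 h (a higher number here means a weaker inhibitor, a lower number a stronger inhibitor), compound 3 shows > 100000 nM and that is a limit, not a number. It shares this position with compound 2 (the limit of > 100000 nM in this assay, at which 2 of the 3 values shown sit).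

Compound 4 `Brc1cccc(CSc2nnc(-c3ccc4c(c3)OCCO4)n2-c2ccccc2)c1` keeps the same atoms as compound 3 but carries 3-bromophenyl in place of 2-bromophenyl on a saturated chain carbon bound to a sulfur.

Two measured steps add a substituted benzyl group to the sulfur of compound 1: an at least 1.9-fold higher number from compound 1 to compound 2 (0.28 log units; that floor lies within the scatter) and an at least 1.9-fold higher number from compound 1 to compound 3 (0.28 log units; that floor lies within the scatter). The step closest to the new change is a step that the two limits leave unreadable from compound 2 to compound 3, so no measured step gives a size for a change among these benzyl groups.

Compound 4 is therefore expected to remain about as weak as compound 2 and compound 3, most likely reported as a limit again. The expected change is a step that the limit leaves unreadable from compound 3 to compound 4, with no step beyond the scatter foreseen.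

For compound 4 the estimate is 110000 nM, within an expected range of 45000 nM to 250000 nM.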

Compound 4, half-maximal inhibitory concentration: 44200 nM
For compound 4 the middle estimate is 2.5-fold (0.40 log units) above the measured one; the measured number lies below the stated range.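

In this assay, replacing 2-bromobenzyl with 3-bromobenzyl on the sulfur gives an at least 2.2-fold lower number from compound 3 to compound 4 (0.35 log units; beyond the scatter), so the place of the bromine on this ring matters even though the atoms stay the same. Keeping that ring place but changing the group also counts: the change of methoxy to bromo gives an at least 2.2-fold lower number from compound 2 to compound 4 (0.35 log units; beyond the scatter). A benzyl group on the sulfur therefore need not cost activity, since adding 3-bromobenzyl gives a 1.2-fold lower number from compound 1 to compound 4 (0.07 log units; within the scatter), while the two other benzyl compounds remain limits: the limit of > 100000 nM in this assay, at which 2 of the 4 values shown sit.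

Compound 2 and compound 3 are both limits, so the step joining them cannot be read. On these data alone, it remains open whether this result is specific to bromine or would also hold for chloro, methyl or a carboxylic acid on the ring, or for a longer chain on the sulfur.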